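Replacing phenyl with chloro on a saturated ring carbon

The source may hold more compounds than are shown below. What is called first, only, known or untested is meant among the compounds shown, and "the series" means these compounds.

compound 1 `CC1=NN(C(=O)CN2CCCCC2)C(c2ccccc2O)C1` gives 4310 nM
compound 2 `CC1=NN(C(=O)CN2CCCC2)C(c2ccccc2O)C1` gives 17900 nM
compound 3 `CC1=NN(C(=O)CN2CCC(c3ccccc3)CC2)C(c2ccccc2O)C1` gives 12300 nM
compound 4 `CC1=NN(C(=O)CN2CCC(Cl)CC2)C(c2ccccc2O)C1` has not yet been measured

These numbers come from a functional assay on MGC-803 cells (Homo sapiens) for cytotoxicity, read by MTT assay, with a stated time of 48 h (on this read-out higher numbers stand for weaker inhibition and lower numbers for stronger inhibition), and compound 3 sits in the upper part of them. Its value lies within the scatter of the value of compound 2, while the gap to the lowest number is a 2.9-fold higher number from compound 1 to compound 3 (0.46 log units; beyond the scatter) and lies beyond the scatter.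

The change considered here is chloro in place of phenyl on a saturated ring carbon which puts chloro in place of phenyl on a saturated ring carbon. The measured step to compound 3 bears most directly, as it concerns this same ring carbon. The other measured step, a 4.2-fold higher number from compound 1 to compound 2 (0.62 log units; beyond the scatter) alters the ring itself and serves only as a gauge of size, and it is also modest. For the measured compounds named here, no measured compound carries chloro, so the data give no direct reading for it.

With hydrogen and phenyl as the two known cases on that carbon, compound 4 is expected to fall between them. The estimated change in this assay is a 1.9-fold lower number from compound 3 to compound 4 (0.28 log units; within the scatter) toward stronger inhibition, a small step expected at the edge of the scatter. Compound 4 is estimated at 6500 nM with 2500 nM to 17000 nM as the expected range.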

Compound 4, half-maximal inhibitory concentration: 30300 nM
For compound 4 the middle estimate is 4.7-fold (0.67 log units) below the measured one; measured number outside the range, above it.
By their numbers in this assay, from the lowest: compound 1; then compounds 3, 2 and 4 (each within the scatter of the next, the first and the last beyond it).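

In this assay, three groups can now be compared on the saturated ring carbon three ring bonds from the ring nitrogen: chloro in place of hydrogen gives a 7.0-fold higher number from compound 1 to compound 4 (0.85 log units; beyond the scatter), while chloro in place of phenyl gives a 2.5-fold higher number from compound 3 to compound 4 (0.39 log units; beyond the scatter). Both groups therefore weaken inhibition relative to hydrogen, and chloro, with its single heavy atom, does so more than phenyl, with its six, so among compounds 1, 3 and 4 the read-out does not follow the heavy-atom count of the group on this carbon. The step of a 1.7-fold higher number from compound 2 to compound 4 (0.23 log units; within the scatter) shows that this chloro compound and the pyrrolidin-1-yl compound cannot be told apart in this assay, and nothing available here explains why chloro and phenyl differ on this carbon.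

The compounds shown leave open whether hydroxyl, methyl or an amine on this ring carbon would also raise the number relative to hydrogen, or whether hydrogen is unusual among such groups. They also leave open whether the same order of hydrogen, phenyl and chloro would hold on the pyrrolidine ring or with another group on the shared core.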